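The source may report more compounds than this note shows. Statements on the series, on what has been measured and on what is new or still open speak of the compounds shown alone.

The measured compounds:

Compound 1, `COc1cccc(-c2csc(NC(=O)c3ccco3)n2)c1`, in an ADME assay on Vero cells (Chlorocebus sabaeus) for cytotoxicity, read by MTT assay, with a stated time of 72 h (on this read-out lower numbers stand for stronger inhibition and higher numbers for weaker inhibition), gives > 90000 nM, which is a limit of the assay rather than a number.
Compound 2, `COc1cccc(-c2csc(NC(=O)c3ccc([N+](=O)[O-])cc3)n2)c1`, gives > 90000 nM, again a limit of the assay.
Compound 3, `CC(=O)Nc1cccc(-c2csc(NC(=O)c3ccc([N+](=O)[O-])o3)n2)c1`, gives 57600 nM.

Compound 3 is thus the only one of the three with an actual number in this assay; the other two fall under (the limit of > 90000 nM in this assay, at which 2 of the 3 values shown sit). No order among the three can be read from this beyond the fact that compound 3 alone yielded a measurable concentration. Among the compounds with values here, since no two of the measured compounds differ in a single place, there is no measured step to lean on.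

Compound 4, `O=C(Nc1nc(-c2cccc(NS(=O)(=O)Cc3ccccc3)c2)cs1)c1ccc([N+](=O)[O-])o1`, is reached from compound 3 by one change: benzylsulfonyl in place of acetyl on a nitrogen on an aromatic ring. Whether benzylsulfonyl in place of acetyl moves the number in this assay cannot be read from the compounds at hand. The step expected in this assay is a 1.4-fold lower number from compound 3 to compound 4 (0.16 log units; within the scatter), towards a somewhat lower concentration, but small enough to lie within the usual scatter or only just beyond it. For compound 4 the estimate is 40000 nM, with a likely range from 15000 nM to 90000 nM.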

Compound 4, half-maximal inhibitory concentration: 59300 nM
Estimate against measurement, compound 4: 1.5-fold (0.17 log units) below; low and high end bracket the measured number.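

In this assay, within the data shown here, this is the first measured step in the set, and it concerns a nitrogen on an aromatic ring: benzylsulfonyl in place of acetyl gives a 1.0-fold higher number from compound 3 to compound 4 (0.01 log units; within the scatter), even though the entering group brings a six-membered aromatic ring that acetyl lacks. At this place, then, the larger group leaves the number indistinguishable from that of the acetyl compound, and both compounds give real numbers rather than a limit of the assay. No measured property among the data explains this result, which stands as an observation only.

The compounds shown leave open how other groups on this nitrogen would read, for example a free amine with neither acetyl nor benzylsulfonyl attached, or a longer chain such as hexanoyl. From the compounds shown here alone, this is also a single pair, so whether benzylsulfonyl in place of acetyl would give the same result on molecules that differ elsewhere in their structure remains unknown.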